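This account rests on a few compounds, and the source may have more. Where it says the series, first, only, none or still open, it means among the compounds named here.

Among the measured compounds shown here, compound 2 `COc1cc(N)c(Cl)cc1NC(=O)C1CCN(Cc2ccc(F)cc2)CC1` is one of two compounds measured so far in a functional assay on the whole organism for antagonist activity, with Mus musculus as the target; on this read-out higher numbers stand for an effect only at larger amounts of compound and lower numbers for an effect already at smaller amounts. In this assay, for the measured compounds named here, compound 2 gives 0.6 mg/kg, while compound 1 `COc1ccc(CN2CCC(C(=O)Nc3cc(Cl)c(N)cc3OC)CC2)cc1` gives 0.9 mg/kg; the single step that separates them, a 1.5-fold lower number from compound 1 to compound 2 (0.18 log units; within the scatter), is within the scatter, so the two compounds stand together on this read-out rather than apart. Compound 3 `COc1cc(N)c(Cl)cc1NC(=O)C1CCN(Cc2ccsc2)CC1` has not yet been measured in this assay. It differs from compound 2 in one place: thiophen-3-yl in place of 4-fluorophenyl on a saturated chain carbon bound to an amine nitrogen in a ring. Going by the values given here, the only measured step available, a 1.5-fold lower number from compound 1 to compound 2 (0.18 log units; within the scatter), concerns a different exchange on the same ring and was within the scatter; no measured step shows what happens when the whole ring on the saturated chain carbon is exchanged for thiophen-3-yl. The expectation for compound 3 therefore rests on the number of compound 2, with nothing in the data pointing to a step beyond the scatter in either direction. The step expected from compound 2 to compound 3 is a 1.3-fold higher number from compound 2 to compound 3 (0.12 log units; within the scatter). Compound 3 is estimated at 0.8 mg/kg, within a range from 0.3 mg/kg to 2.5 mg/kg.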

Compound 3, dose for half-maximal effect: 3.4 mg/kg
The estimate for compound 3 lay 4.3-fold (0.63 log units) below the measured number; the whole stated range lies below it.
By their numbers in this assay, from the lowest: compounds 2 and 1 (each within the scatter of the next); then compound 3.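

In this assay, the group on the saturated chain carbon bound to an amine nitrogen in a ring proves sensitive to exchange of the whole ring: thiophen-3-yl in place of 4-fluorophenyl gives a 5.7-fold higher number from compound 2 to compound 3 (0.75 log units; beyond the scatter), and thiophen-3-yl in place of 4-methoxyphenyl gives a 3.8-fold higher number from compound 1 to compound 3 (0.58 log units; beyond the scatter). Exchanging the substituent on the six-membered carbon ring had left compound 1 and compound 2 within the scatter, whereas moving to this five-membered ring with one sulfur atom means that a larger dose is needed, whichever of the two compounds serves as the starting point. No measurement shown here explains why this exchange has such an effect. The three compounds cannot separate the change in ring size from the entry of sulfur, or from the loss of a substituent on the ring, since all of these happen together in both steps. From the compounds shown here alone, an unsubstituted phenyl ring, a thiophen-2-yl group or a furan-3-yl group would each be needed to tell these apart, and how any of them would stand in this assay remains open.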